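A few compounds are considered here, and "the series" means these few. Any claim that something is new, unique, unknown or untested is made for them only; others in the source may bear on it.

Measured compounds:
- compound 1, `Cc1cc(C)n(C)c(=O)c1CN1CCc2c(Cl)cc(-c3c(C)noc3C)c(Cl)c2C1=O`, in an assay on isolated protein for inhibition of histone-lysine N-methyltransferase EZH2 (Homo sapiens), read by filter binding, with a stated time of 1 h (on this read-out lower numbers stand for stronger inhibition and higher numbers for weaker inhibition), compound 1 gives 14 nM
- compound 2, `Cc1noc(C)c1-c1cc(Cl)c2c(c1Cl)C(=O)N(Cc1c(C3CC3)cc(C)n(C)c1=O)CC2`, in this assay compound 2 gives 302 nM

Among the measured compounds shown here, compound 2 stands at the higher of the two numbers measured, with compound 1 the only neighbour, and the gap is large: a 22-fold higher number from compound 1 to compound 2 (1.33 log units; beyond the scatter), the sole structural change being cyclopropyl in place of methyl on an aromatic carbon.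

Compound 3, `Cc1noc(C)c1-c1cc(Cl)c2c(c1Cl)C(=O)N(Cc1c(C(F)(F)F)cc(C)n(C)c1=O)CC2`, is not yet measured. It differs from compound 2 in one place: trifluoromethyl in place of cyclopropyl on an aromatic carbon.

For the measured compounds named here, the only measured step that bears on this position is the one from compound 1 to compound 2, which showed that exchanging the group on this aromatic carbon can move the number a long way. That step went from methyl to cyclopropyl; the present change goes from cyclopropyl to trifluoromethyl, so neither end of the new pair has been seen before at this position. Compound 3 is therefore expected to lie between the two measured values, with the step of a 3.0-fold lower number from compound 2 to compound 3 (0.48 log units; beyond the scatter) estimated as a moderate lowering. Compound 3 is estimated at 100 nM, within a range of 30 nM to 400 nM.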

Compound 3, half-maximal inhibitory concentration: > 1000 nM
Compound 3 ended at the assay's limit; the forecaster's own chance of this, stated with the estimate: 0%; at least 10-fold (1.00 log units) between middle value and limit.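

In this assay, going by these compounds, compound 3 gives > 1000 nM, which is a limit of the assay and not a number, so its steps give only a minimum size and the true distance from the other compounds stays unknown: the limit of > 1000 nM in this assay, at which 1 of the 3 values shown sits. At the aromatic carbon opposite the ring nitrogen, the exchange of cyclopropyl for trifluoromethyl gives an at least 3.3-fold higher number from compound 2 to compound 3 (0.51 log units; beyond the scatter), which shows that replacing cyclopropyl here need not recover the number lost on leaving methyl. Trifluoromethyl in place of methyl gives an at least 71-fold higher number from compound 1 to compound 3 (1.85 log units; beyond the scatter), so both groups shown as replacements for methyl raise the number, and among these three compounds methyl alone gives a value in the low range.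

The compounds shown leave open whether anything other than methyl at this carbon can match or improve on compound 1, for example an ethyl group, a methoxy group, a chlorine atom or plain hydrogen. Among the compounds shown here, they also leave open whether the same order of these groups would hold on a core other than the one shared by compound 1, compound 2 and compound 3.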